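Extending the chain on the carbonyl of compound 2

The source may report more compounds than this note shows. Statements on the series, on what has been measured and on what is new or still open speak of the compounds shown alone.

Measured compounds (a functional assay on IMR-32 cells (Homo sapiens) for inhibition, with a stated time of 48 h, tested at 50 uM; a higher number here means more inhibition of growth at the concentration tested, a lower number less inhibition of growth)
compound 1 `C=C[C@@](C)(/C=C/c1ccc(OC(C)=O)cc1)CCC=C(C)C`: 71%
compound 2 `C=C[C@@](C)(/C=C/c1ccc(OC(=O)CCC)cc1)CCC=C(C)C`: 54%

Compound 2 stands at 54% in this assay and is the lower of the two measured compounds. Compound 3 `C=C[C@@](C)(/C=C/c1ccc(OC(=O)CCCC)cc1)CCC=C(C)C` has not been measured yet. Its structural change is methyl in place of hydrogen on a saturated chain carbon, three bonds along the chain from a carbonyl carbon so that propyl becomes butyl, on a saturated chain carbon, three bonds along the chain from a carbonyl carbon.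

Going by the values given here, only one measured step bears on this change. It is a number 17 percentage points lower from compound 1 to compound 2 (beyond the scatter) and it came from ethyl in place of hydrogen on a saturated chain carbon bound to a carbonyl carbon. A single step cannot establish a trend, so the size of the next one is uncertain. Going by a number 17 percentage points lower from compound 1 to compound 2 (beyond the scatter) the expected direction is downward, and since methyl is a smaller addition than ethyl, a smaller step is expected. The expected change is a number 7 percentage points lower from compound 2 to compound 3 (within the scatter) and it may not stand clear of the scatter. The estimate for compound 3 is 47% with 32% to 62% as its expected range.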

Compound 3, percent growth inhibition at one concentration: 21%
Compound 3: the middle estimate sits 26 percentage points above what was measured, and the stated range ends above it.
By their numbers in this assay, from the lowest: compound 3; then compound 2; then compound 1.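

In this assay, methyl in place of hydrogen on a saturated chain carbon, three bonds along the chain from a carbonyl carbon, turns propyl into butyl and gives a number 33 percentage points lower from compound 2 to compound 3 (beyond the scatter), a large step from a single added carbon, whereas the earlier addition of ethyl gave only a modest one, a number 17 percentage points lower from compound 1 to compound 2 (beyond the scatter). Taken together, the two additions give a number 50 percentage points lower from compound 1 to compound 3 (beyond the scatter), so among these three compounds the number falls as the chain grows, none goes against that order, and the fall is uneven rather than steady, with the smaller addition bringing the larger step. Nothing measured here accounts for the size of this last step.

Going by these compounds, what remains open is whether a longer chain, such as pentyl, would lower the number further or whether the fall would level off. Also open, on these data alone, is whether a chain of similar length ending in an amine or a carboxylic acid would follow the same course at this position.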